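A few compounds are considered here, and "the series" means these few. Any claim that something is new, unique, unknown or untested is made for them only; others in the source may bear on it.

Series notes. Compound 1 `CC(=O)Nc1ccc(S(=O)(=O)Oc2ccccc2C(C)C)cc1` gives 21000 nM in a functional assay on M21 cells (Homo sapiens) for antiproliferative activity, read by sulforhodamine B assay, with a stated time of 48 h; a higher number here means a weaker inhibitor, a lower number a stronger inhibitor. Compound 2 `CC(C)c1ccccc1OS(=O)(=O)c1ccc(NC(=O)C(C)(C)C)cc1` gives 6200 nM in this assay; the step of a 3.4-fold lower number from compound 1 to compound 2 (0.53 log units; beyond the scatter) is the one clear move in the set. Compound 3 `CC(C)(C)C(=O)Nc1ccc(S(=O)(=O)Oc2ccccc2I)cc1` gives 8300 nM in this assay, and the step of a 1.3-fold higher number from compound 2 to compound 3 (0.13 log units; within the scatter) adds nothing beyond the scatter. Compound 3 therefore stands second highest of the three numbers, close to compound 2 and apart from compound 1 only by the move that arose at the carbonyl carbon.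

Compound 4 `CCNC(=O)Nc1ccc(S(=O)(=O)Oc2ccccc2I)cc1` is the next member: ethylamino in place of tert-butyl on a carbonyl carbon. Within the data shown here, the change again sits on the carbonyl carbon, so the only step that bears on it is a 3.4-fold lower number from compound 1 to compound 2 (0.53 log units; beyond the scatter), where tert-butyl in place of methyl brought the number down; the step of a 1.3-fold higher number from compound 2 to compound 3 (0.13 log units; within the scatter) concerns the other ring and says nothing here. With tert-butyl leaving that carbon, the number for compound 4 is expected to drift back toward that of compound 1, by a 1.8-fold higher number from compound 3 to compound 4 (0.26 log units; within the scatter). Compound 4 is thus estimated at 15000 nM, with a range of 6000 nM to 40000 nM.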

Compound 4, half-maximal inhibitory concentration: 5600 nM
The estimate for compound 4 lay 2.7-fold (0.43 log units) above the measured number; the whole stated range lies above it.
By their numbers in this assay, from the lowest: compounds 4, 2 and 3 (each within the scatter of the next); then compound 1.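

At the carbonyl carbon, ethylamino in place of tert-butyl gives a 1.5-fold lower number from compound 3 to compound 4 (0.17 log units; within the scatter) in this assay, so this exchange leaves the number unchanged within the scatter. Tert-butyl is therefore not the only group at this carbon compatible with a number in this range, even though ethylamino carries a hydrogen-bond donor that tert-butyl lacks, and methyl gave a 3.4-fold lower number from compound 1 to compound 2 (0.53 log units; beyond the scatter) with isopropyl present on the other ring. No available evidence bears on this result.

From the compounds shown here alone, it remains open whether a longer chain on the nitrogen, such as butylamino, or a cyclic amine such as piperidine at the same carbon would hold the number or move it beyond the scatter. Going by these compounds, whether ethylamino behaves the same way with isopropyl in place of iodo also remains open.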